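The compounds below may be only part of what the source reports. "The series", "measured", "known", "first", "only" and "open" are said of these compounds alone.

Measured compounds in a physicochemical assay for lipophilicity; on this read-out higher numbers stand for higher lipophilicity and lower numbers for lower lipophilicity:
- compound 1 `C[n+]1ccn(COCCCS(C)(=O)=O)c1/C=N/O`: -2.5
- compound 2 `CCN(CCn1cc[n+](C)c1/C=N/O)S(=O)(=O)C(F)(F)F`: -1.03
- compound 3 `C[n+]1ccn(CCCS(C)(=O)=O)c1/C=N/O`: -2.7

Three compounds of the series have a number in this assay. Compound 1 sits within the usual scatter of compound 3, so the two cannot be told apart on this read-out. Within the data shown here, compound 2 stands well apart from both, beyond the scatter, with the highest lipophilicity of the three; the oxime-bearing core is shared, so the gap reflects the differing side chains, and no single-point step between measured compounds is available to attribute it further.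

Compound 4 `CCS(=O)(=O)CCOCn1cc[n+](C)c1/C=N/O` has not yet been measured. It differs from compound 1 in one place: ethylsulfonyl in place of (methylsulfonyl)methyl on a saturated chain carbon, two bonds along the chain from an oxygen on a saturated carbon. The two compounds hold the same atoms, joined differently, with the sulfone moved one bond further along the chain and its alkyl substituent lengthened by the carbon taken from the chain.

Among the measured compounds shown here, no measured pair isolates such a rearrangement, so there is no step to lean on. With the same atom count, the same acceptor count and no change in charge, the expected step from compound 1 to compound 4 is none beyond the scatter, so a number 0.10 log units higher from compound 1 to compound 4 (within the scatter) is the expectation. Compound 4 is therefore estimated at -2.4, within -2.9 to -1.9.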

Compound 4, distribution coefficient: < -2.7
Compound 4 gave a limit, no number; the forecaster's own chance of this, stated with the estimate: 5%; middle value at least 0.30 log units away from the limit.
By their numbers in this assay, from the lowest: compounds 3 and 1 (each within the scatter of the next); then compound 2.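

In this assay compound 4 gives < -2.7, which is a limit and not a number. Among these compounds, this is the only step that can be read at this position: ethylsulfonyl in place of (methylsulfonyl)methyl, on a saturated chain carbon, two bonds along the chain from an oxygen on a saturated carbon, with the same atoms joined differently, gives a number at least 0.20 log units lower from compound 1 to compound 4 (that floor lies within the scatter). The earlier compounds held no such pair, and the step now shows that the read-out does not rise with this rearrangement, though its full size remains unread and the printed floor alone cannot place the change beyond the scatter: the limit of < -2.7 in this assay, at which 1 of the 4 values shown sits.

On these data alone, the actual size of the step stays open until a number replaces the limit, so no ranking of the two sulfone arrangements beyond this direction can be given. Also open is how this position responds to other groups, such as a longer chain on the sulfone (propylsulfonyl) or an amine or carboxylic acid in place of the sulfone, since the compounds shown hold only sulfone and sulfonamide side chains.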